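Ring contraction with a carbamoyl cyclobutyl on the anilino nitrogen

The source may hold more compounds than are shown below. What is called first, only, known or untested is meant among the compounds shown, and "the series" means these compounds.

The series shares one core and varies the ring on a nitrogen on an aromatic ring. Compound 1 `N#Cc1cnc(NCc2cnccc2C(F)(F)F)cc1N[C@H]1C[C@H](O)C1` gives 900 nM in an assay on isolated protein for inhibition of protein kinase C theta type (Homo sapiens), read by TR-FRET, with a stated time of 2 h; a higher number here means a weaker inhibitor, a lower number a stronger inhibitor. Compound 2 `N#Cc1cnc(NCc2cnccc2C(F)(F)F)cc1N[C@H]1CC[C@@H](O)CC1` gives 100 nM in this assay, and compound 3 `CC1(C)C[C@H](Nc2cc(NCc3cnccc3C(F)(F)F)ncc2C#N)CC[C@H]1O` gives 100 nM. The move to a six-membered ring carries the change a 9.0-fold lower number from compound 1 to compound 2 (0.95 log units; beyond the scatter) and, with the gem-dimethyl present, a 9.0-fold lower number from compound 1 to compound 3 (0.95 log units; beyond the scatter); between the two six-membered analogues there is no change at the digits printed from compound 2 to compound 3 (within the scatter). Compound 3 therefore stands level with compound 2, the two together at the lowest numbers of the three, with compound 1 furthest away.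

Compound 4 `CC1(C)[C@@H](C(N)=O)C[C@H]1Nc1cc(NCc2cnccc2C(F)(F)F)ncc1C#N` brings the change (3-carbamoyl-2,2-dimethylcyclobutyl in place of 4-hydroxy-3,3-dimethylcyclohexyl on a nitrogen on an aromatic ring). The measured steps that bear on it are the two ring-size steps from compound 1, each a modest step beyond the scatter, and the neutral step from compound 2 to compound 3, which shows the dimethyl pattern itself costs nothing. Returning to a four-membered ring is the reverse of those steps; the carbamoyl in place of the hydroxy group has no precedent here. Compound 4 is expected to sit near 500 nM, between 150 nM and 2000 nM. The step of a 5.0-fold higher number from compound 3 to compound 4 (0.70 log units; beyond the scatter) is thus estimated as a modest loss.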

Compound 4, half-maximal inhibitory concentration: 1.4 nM
The estimate for compound 4 lay 360-fold (2.55 log units) above the measured number; the measured number lies below the stated range.
By their numbers in this assay, from the lowest: compound 4; then compounds 2 and 3 (each within the scatter of the next); then compound 1.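

At the position on a nitrogen on an aromatic ring, a four-membered ring is not the weak choice that compound 1 suggested: in this assay the 3-carbamoyl-2,2-dimethylcyclobutyl group brings a 71-fold lower number from compound 3 to compound 4 (1.85 log units; beyond the scatter) and a 71-fold lower number from compound 2 to compound 4 (1.85 log units; beyond the scatter), which places compound 4 at the lowest number of the four. Going by these compounds alone, the ring-size reading from the earlier compounds therefore holds only for the hydroxy-bearing rings, as the step of a 640-fold lower number from compound 1 to compound 4 (2.81 log units; beyond the scatter) far exceeds the step of a 9.0-fold lower number from compound 1 to compound 2 (0.95 log units; beyond the scatter) and runs with no enlargement of the ring at all. No measurement on hand accounts for this drop in the number.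

Compound 4 differs from compound 1 in the carbamoyl and the two methyl groups at once, so the share of each in the step stays unresolved, and the neutral step of no change at the digits printed from compound 2 to compound 3 (within the scatter) on the six-membered ring cannot be carried over to the four-membered one. Also open, going by these compounds, is whether the primary amide itself is what counts, a question that a carboxylic acid, a methyl ester or an N-methyl amide on the same cyclobutyl ring would address, as would the other stereoisomers of the ring.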